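Sulfonyl aryl variants and a tert-butyl replacement

The source may report more compounds than this note shows. Statements on the series, on what has been measured and on what is new or still open speak of the compounds shown alone.

Measured in an assay on HEK293 cells for displacement of a labelled ligand from 5-hydroxytryptamine receptor 6 (Homo sapiens); a lower number here means a stronger inhibitor, a higher number a weaker inhibitor:
compound 1, `O=S(=O)(c1cccc2ccccc12)N1CCOc2c(N3CCNCC3)cc(Cl)cc21`: 0.794 nM
compound 2, `O=S(=O)(c1cccc2cccnc12)N1CCOc2c(N3CCNCC3)cc(Cl)cc21`: 0.631 nM
compound 3, `O=S(=O)(c1ccccc1F)N1CCOc2c(N3CCNCC3)cc(Cl)cc21`: 0.398 nM

Compound 3 has the lowest number of the three, but the steps of a 2.0-fold lower number from compound 1 to compound 3 (0.30 log units; within the scatter) and a 1.6-fold lower number from compound 2 to compound 3 (0.20 log units; within the scatter) both fall within the scatter, as does a 1.3-fold lower number from compound 1 to compound 2 (0.10 log units; within the scatter); the three sulfonyl aryl groups are not separated.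

Compound 4, `CC(C)(C)c1cc(N2CCNCC2)c2c(c1)N(S(=O)(=O)c1ccccc1F)CCO2`, keeps the 2-fluorophenyl of compound 3 and changes the core: tert-butyl in place of chloro on an aromatic carbon. Within the data shown here, none of the measured steps touches this position; all of them vary the group on the sulfonyl sulfur, so no measured step bears on the change directly. Among the measured compounds shown here, with no precedent, the expected step of a 2.5-fold higher number from compound 3 to compound 4 (0.40 log units; beyond the scatter) is none beyond the scatter, with a wide range. Compound 4 is estimated at 1 nM, between 0.3 nM and 4 nM.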

Compound 4, inhibition constant: 7.94 nM
For compound 4 the middle estimate is 7.9-fold (0.90 log units) below the measured one, outside the stated range (above it).
By their numbers in this assay, from the lowest: compounds 3, 2 and 1 (each within the scatter of the next); then compound 4.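

Among these compounds, the aromatic carbon meta to a piperazin-1-yl group, untouched by the earlier steps, proves sensitive: tert-butyl in place of chloro gives a 20-fold higher number from compound 3 to compound 4 (1.30 log units; beyond the scatter). This is the only step beyond the scatter among the compounds shown, whereas the sulfonyl aryl variants of compounds 1, 2 and 3 remain unseparated. No evidence on hand accounts for this step.

Open, as far as these compounds go, is how other groups at this carbon, such as methyl, methoxy or fluoro, compare with chloro and tert-butyl. Also open, from the compounds shown here alone, is whether the step holds with naphthalen-1-yl or quinolin-8-yl on the sulfonyl sulfur.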